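The compounds below may be only part of what the source reports. "The series", "measured", "known", "first", "only" and "open" are said of these compounds alone.

In a functional assay on Raji cells (Homo sapiens) for antiproliferative activity, read by MTT assay, with a stated time of 72 h (on this read-out higher numbers stand for weaker inhibition and lower numbers for stronger inhibition), compound 1 `CN(Cc1nc(C2CCN(Cc3ccccc3)CC2)no1)c1ncc(C(=O)NO)cn1` gives 27.6 nM and compound 2 `CN(Cc1nc(C2CCN(Cc3ccc(F)cc3)CC2)no1)c1ncc(C(=O)NO)cn1` gives 22 nM. Compound 3 `CN(Cc1nc(C2CCN(Cc3ccc(C#N)cc3)CC2)no1)c1ncc(C(=O)NO)cn1` gives 117 nM, the highest number of the three. Compound 4 `CN(Cc1nc(C2CCN(Cc3ccc(F)cc3Cl)CC2)no1)c1ncc(C(=O)NO)cn1` differs from compound 3 in one place: 2-chloro-4-fluorophenyl in place of 4-cyanophenyl on a saturated chain carbon bound to an amine nitrogen in a ring. Among the compounds with values here, three measured steps bear on this change. Cyano in place of hydrogen gave a 4.2-fold higher number from compound 1 to compound 3 (0.63 log units; beyond the scatter), and cyano in place of fluoro gave a 5.3-fold higher number from compound 2 to compound 3 (0.73 log units; beyond the scatter). Fluoro in place of hydrogen gave a 1.3-fold lower number from compound 1 to compound 2 (0.10 log units; within the scatter). Compound 4 loses the cyano and carries the fluoro seen in compound 2 at 22 nM, so a modest drop is expected in this assay. Within the data shown here, no measured compound shows what the chloro does. The expected change is a 4.7-fold lower number from compound 3 to compound 4 (0.67 log units; beyond the scatter). Compound 4 is estimated at 25 nM, with an expected range from 10 nM to 65 nM.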

Compound 4, half-maximal inhibitory concentration: 116 nM
Estimate against measurement, compound 4: 4.6-fold (0.67 log units) below, and the stated range ends below it.
By their numbers in this assay, from the lowest: compounds 2 and 1 (each within the scatter of the next); then compounds 4 and 3 (each within the scatter of the next).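

In this assay, the swap of 4-cyanophenyl for 2-chloro-4-fluorophenyl leaves the number unchanged within the scatter, with a 1.0-fold lower number from compound 3 to compound 4 (0.00 log units; within the scatter). Chloro in place of hydrogen gives a 5.3-fold higher number from compound 2 to compound 4 (0.72 log units; beyond the scatter), and the whole change from phenyl gives a 4.2-fold higher number from compound 1 to compound 4 (0.62 log units; beyond the scatter), so a cyano is not the only group on this ring that comes with a higher number. No measurement shown here explains this result. Going by these compounds, whether chloro alone, without the fluoro, behaves the same remains open. So does the outcome with a methoxy group or an amine on this ring.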